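2,6-dichlorobenzyl to 2,6-difluorobenzyl against a cytotoxicity limit

The compounds below may be only part of what the source reports. "The series", "measured", "known", "first", "only" and "open" are said of these compounds alone.

In an ADME assay on MT4 cells (Homo sapiens) for cytotoxicity, read by MTT assay (on this read-out higher numbers stand for lower toxicity in this test and lower numbers for higher toxicity in this test), compound 1 `COc1ccc(C(=O)CSc2nc(Cc3c(Cl)cccc3Cl)c(C)c(=O)[nH]2)cc1` gives > 56000 nM as a limit and not a number. Compound 2 `CCc1c(Cc2c(Cl)cccc2Cl)nc(SCC(=O)c2ccc(OC)cc2)[nH]c1=O` gives > 54000 nM as a limit too. For the measured compounds named here, compound 1 therefore has no number of its own, and the only other value is also a limit. Compound 3 `COc1ccc(C(=O)CSc2nc(Cc3c(F)cccc3F)c(C)c(=O)[nH]2)cc1` differs from compound 1 in one place: 2,6-difluorophenyl in place of 2,6-dichlorophenyl on a saturated chain carbon bound to an aromatic carbon with 2,6-difluorophenyl in place of 2,6-dichlorophenyl on a saturated chain carbon bound to an aromatic carbon. Going by the values given here, the only measured step is a step that the two limits leave unreadable from compound 1 to compound 2 and it is a different change with no readable size, so it offers no size to carry over. No step beyond the scatter is expected in this assay and the estimated step is a step that the limit leaves unreadable from compound 1 to compound 3 with no clear direction. A limit is again the expected report. For compound 3 the expected value is 60000 nM (estimated range 25000 nM to 90000 nM).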

Compound 3, half-maximal cytotoxic concentration: > 60000 nM
Compound 3 gave a limit, no number (the forecaster's own chance of this, stated with the estimate: 75%); the middle value sits exactly at the limit.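

The results for compound 1 and compound 3 in this assay are both limits and not numbers, so no step can be read between them. The compounds shown leave open where the half-maximal cytotoxic concentration of either compound lies, and whether 2,6-difluorobenzyl in place of 2,6-dichlorobenzyl shifts it.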